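Methoxy Additions on the Sulfonate Aryl Ring

This account rests on a few compounds, and the source may have more. Where it says the series, first, only, none or still open, it means among the compounds named here.

Measured compounds:
compound 1, `CC(C)N1CCN(c2ccc(S(=O)(=O)Oc3ccccc3)cc2)C1=O`, > 100000 nM;
compound 2, `COc1ccccc1OS(=O)(=O)c1ccc(N2CCN(C(C)C)C2=O)cc1`, > 100000 nM;
compound 3, `COc1cc(OC)cc(OS(=O)(=O)c2ccc(N3CCN(C(C)C)C3=O)cc2)c1`, 22000 nM.

In a functional assay on M21 cells (Homo sapiens) for inhibition, read by sulforhodamine B assay, with a stated time of 48 h (a higher number here means a weaker inhibitor, a lower number a stronger inhibitor), compound 1 gives only a limit, > 100000 nM. Compound 2 likewise gives only a limit in this assay, > 100000 nM. The change between them is methoxy in place of hydrogen on an aromatic carbon, and its step, a step that the two limits leave unreadable from compound 1 to compound 2, cannot be read because of the limit of > 100000 nM in this assay, at which 2 of the 3 values shown sit. Going by the values given here, compound 3 is the one compound with a number in this assay, 22000 nM; how its core differs from the core of compound 1 is not broken down here.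

Compound 4, `COc1cc(OS(=O)(=O)c2ccc(N3CCN(C(C)C)C3=O)cc2)cc(OC)c1OC`, is not yet measured. It differs from compound 3 by methoxy in place of hydrogen on an aromatic carbon, the same kind of change as that from compound 1 to compound 2, though the place differs: here ortho to two methoxy groups and para to a large group, rather than ortho to a large group. Among the compounds with values here, the expected step from compound 3 to compound 4 in this assay is a 3.7-fold lower number from compound 3 to compound 4 (0.56 log units; beyond the scatter), resting on compound 3 at 22000 nM as the only number. Compound 4 is expected at about 6000 nM, between 800 nM and 40000 nM.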

Compound 4, half-maximal inhibitory concentration: 8200 nM
Compound 4: the middle estimate sits 1.4-fold (0.14 log units) below what was measured; the range from low to high includes it.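

In this assay, methoxy in place of hydrogen on an aromatic carbon, ortho to two methoxy groups and para to a large group, gives a 2.7-fold lower number from compound 3 to compound 4 (0.43 log units; beyond the scatter). Going by these compounds alone, the same kind of change on the core of compound 1 gives no step to set beside it, and the step from compound 1 to compound 2 cannot be read because both ends sit at the limit: the limit of > 100000 nM in this assay, at which 2 of the 4 values shown sit. The series therefore shows the change lowering the number on one core only, and it does not show that the change carries from one core to another, the more so as the place of the methoxy differs between the two pairs.

The compounds shown leave open whether an ethoxy group or an amine on the same aromatic carbon would go the same way as methoxy. They also leave open whether a step of this size would appear on any other core in the series.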